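The compounds below may be only part of what the source reports. "The series", "measured", "known", "first", "only" and "open" are said of these compounds alone.

Measured so far in a functional assay on PC-3 cells (Homo sapiens) for antiproliferative activity, with a stated time of 72 h; a higher number here means a weaker inhibitor, a lower number a stronger inhibitor:
- compound 1 `COc1cc(O)c2c(=O)cc(-c3ccccc3Cl)oc2c1CN1CCCCC1` gives 63400 nM
- compound 2 `COc1cc(OC)c(C(=O)/C=C/c2ccccc2Cl)c(O)c1CN(C)C` gives 400 nM

Compound 1 holds the higher of the two numbers, which makes it the weaker inhibitor, and its gap to compound 2 lies beyond the usual scatter of repeated measurements. Compound 3 `COc1cc(OC)c2c(=O)cc(-c3ccccc3Cl)oc2c1CN1CCCCC1` keeps the core of compound 1 and alters one place: methyl in place of hydrogen on an oxygen on an aromatic ring with methyl in place of hydrogen on an oxygen on an aromatic ring, so hydroxy becomes methoxy.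

Among the compounds with values here, no measured pair shows this change alone. Compound 2 differs from compound 1 in more than this one place, so it offers no direct guide. A modest move toward a lower number is expected in this assay (a 2.1-fold lower number from compound 1 to compound 3 (0.32 log units; beyond the scatter)), and a result within the scatter would be no surprise. Compound 3 is expected near 30000 nM (estimated range 6000 nM to 100000 nM).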

Compound 3, half-maximal inhibitory concentration: 15500 nM
For compound 3 the middle estimate is 1.9-fold (0.29 log units) above the measured one; the range from low to high includes it.
By their numbers in this assay, from the lowest: compound 2; then compound 3; then compound 1.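

In this assay, replacing hydroxy with methoxy on the core of compound 1 gives a 4.1-fold lower number from compound 1 to compound 3 (0.61 log units; beyond the scatter), so the hydrogen on this oxygen can give way to methyl without a rise in the number. Within the data shown here, this is the first comparison here that isolates a single place, as compound 1 and compound 2 differ in more than one and could not speak to this position. Nothing shown here accounts for the drop in the number.

From the compounds shown here alone, whether a larger group on the same oxygen, such as ethoxy or a longer chain ending in an amine, would lower the number further remains open. This single step also leaves open whether the same change would act similarly on a different core.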